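Series notes: aryl amide analogues, cell growth inhibition

The compounds below may be only part of what the source reports. "The series", "measured", "known", "first", "only" and "open" are said of these compounds alone.

Measured compounds:
compound 1 `CCc1ccc(-c2nn3cc(-c4cccc(N)c4)nc3s2)cc1`, 8200 nM
compound 2 `C=C(Br)C(=O)Nc1cccc(-c2cn3nc(-c4ccc(CC)cc4)sc3n2)c1`, 3300 nM

Both compounds were tested in a functional assay on FM3A cells (Mus musculus) for inhibition, read by cell counting, with a stated time of 2 days; on this read-out higher numbers stand for weaker inhibition and lower numbers for stronger inhibition. Within the data shown here, compound 1 gives 8200 nM and compound 2 gives 3300 nM; the only step measured so far, a 2.5-fold lower number from compound 1 to compound 2 (0.40 log units; beyond the scatter), places compound 2 at the lowest number of the two, with compound 1 as its nearest neighbour.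

Compound 3 `C=C(Br)C(=O)Nc1cccc(-c2cn3nc(-c4ccc(F)cc4)sc3n2)c1` is not yet measured. It differs from compound 2 by fluoro in place of ethyl on an aromatic carbon. Among the measured compounds shown here, no measured step in this set touches that ring: the single step on hand concerns the amide and says nothing about the group para to a large group. For the measured compounds named here, with no bearing step, the expectation for a 1.1-fold higher number from compound 2 to compound 3 (0.03 log units; within the scatter) is a change of no more than the scatter, in no particular direction. Compound 3 is therefore estimated at 3500 nM, within 1100 nM to 11000 nM.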

Compound 3, half-maximal inhibitory concentration: 610 nM
Beside the measured number, compound 3's estimate is 5.7-fold (0.76 log units) above it; measured number outside the range, below it.
By their numbers in this assay, from the lowest: compound 3; then compound 2; then compound 1.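

In this assay, among these compounds, the position para to a large group proves able to move the number, a point the earlier compounds could not address because they share the 4-ethylphenyl group. With the amide unchanged, 4-ethylphenyl to 4-fluorophenyl gives a 5.4-fold lower number from compound 2 to compound 3 (0.73 log units; beyond the scatter), so this aromatic carbon joins the amide nitrogen as a place where a single change registers. The lower number comes with one heavy atom in place of two and with no change in the hydrogen-bond donor or acceptor counts, and nothing on hand accounts for it.

Still open, from the compounds shown here alone, is where a chloro, a methoxy or a plain hydrogen at this position would fall relative to fluoro and ethyl. Going by these compounds, it is also open whether the fluoro step holds when the free amine of compound 1 replaces the bromoethenyl amide.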